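This account rests on a few compounds, and the source may have more. Where it says the series, first, only, none or still open, it means among the compounds named here.

Compound 2, `COC(=O)c1cc(-c2cccc(NC(=O)c3ccc(/C=C/C(=O)c4cc(OC)c(OC)c(OC)c4)cc3)c2)on1`, carries an amide linking an aromatic ester core to a chalcone-like arm. In an ADME assay on Vero cells (Chlorocebus sabaeus) for cytotoxicity, read by MTT assay, with a stated time of 72 h (on this read-out higher numbers stand for lower toxicity in this test and lower numbers for higher toxicity in this test), compound 2 gives > 50 ug/mL, which is a limit of the assay rather than a number. Its nearest measured neighbour is compound 1, `COC(=O)c1cc(-c2cccc(NC(=O)c3ccc(/C=C/C(=O)c4ccccc4)cc3)c2)on1`. In this assay compound 1 gives > 50 ug/mL, again a limit rather than a number. The step that the two limits leave unreadable from compound 1 to compound 2 therefore has no readable size, and compound 2 simply stands where compound 1 stands, as the limit of > 50 ug/mL in this assay, at which 2 of the 2 values shown sit, shows.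

Compound 3, `COC(=O)c1cc(-c2cccc(NC(=O)c3ccc(/C=C/C(=O)c4ccc(OC)cc4OC)cc3)c2)on1`, has not yet been measured. It differs from compound 2 by 2,4-dimethoxyphenyl in place of 3,4,5-trimethoxyphenyl on a carbonyl carbon. Within the data shown here, the only measured step that touches this part of the molecule is a step that the two limits leave unreadable from compound 1 to compound 2, and because both of its ends sit on the limit of > 50 ug/mL in this assay, at which 2 of the 2 values shown sit, it cannot say whether swapping methoxy groups on this ring moves the read-out at all. No step beyond the scatter is expected in either direction. The expected value for compound 3 is 60 ug/mL, within a range from 30 ug/mL to 120 ug/mL. This estimate corresponds to an expected step that the limit leaves unreadable from compound 2 to compound 3.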

Compound 3, half-maximal cytotoxic concentration: > 50 ug/mL
Compound 3: only a limit was reported (the forecaster's own chance of this, stated with the estimate: 75%); the middle value does not contradict the limit.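

In this assay compound 3 gives > 50 ug/mL as a limit of the assay and not a number. The steps joining compound 3 to compound 1 and compound 2 cannot be read: the limit of > 50 ug/mL in this assay, at which 3 of the 3 values shown sit. In this assay the compounds shown leave open whether phenyl, 3,4,5-trimethoxyphenyl and 2,4-dimethoxyphenyl on the carbonyl carbon differ at all.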